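The source may hold more compounds than are shown below. What is called first, only, known or untested is meant among the compounds shown, and "the series" means these compounds.

Measured so far in an ADME assay on a cell-free system (plasma) for protein binding, read by HPLC:
compound 1 `Cc1cn(Cc2ccc(Cl)cc2Cl)c2c(-c3nnc(NS(=O)(=O)c4cc(Cl)c(Cl)s4)o3)cc(F)cc12`: 99.8%
compound 2 `Cc1cn(Cc2ccc(Cl)cc2Cl)c2c(-c3nnc(NS(=O)(=O)c4cc(F)c(F)cc4F)o3)cc(F)cc12`: 99.4%

Of these two, compound 2 has the higher unbound fraction, and its gap to compound 1 lies beyond the scatter. Compound 3 `Cc1cn(Cc2ccc(Cl)cc2Cl)c2c(-c3nnc(NS(=O)(=O)c4ccc(Cl)c(Cl)c4)o3)cc(F)cc12` differs from compound 2 as follows: 3,4-dichlorophenyl in place of 2,4,5-trifluorophenyl on a sulfonyl sulfur. Among the compounds with values here, one measured step bears on this change: a 3.0-fold higher unbound fraction from compound 1 to compound 2 (0.48 log units; beyond the scatter). That modest step brought in 2,4,5-trifluorophenyl in place of 4,5-dichlorothiophen-2-yl on the same sulfonyl sulfur. The present change removes the same group but brings in a different one, so the step is only a rough guide. A somewhat smaller step in the opposite direction is expected in this assay, towards less free compound. The expected step is a 2.0-fold lower unbound fraction from compound 2 to compound 3 (0.30 log units; within the scatter). The estimate for compound 3 is 99.7%, with an expected range of 99.3% to 99.9%.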

Compound 3, plasma protein binding: 97.2%
For compound 3 the middle estimate is 9.3-fold (0.97 log units) (unbound fraction) below the measured one; the whole stated range lies above it.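

On the sulfonyl sulfur, 3,4-dichlorophenyl gives the largest shifts yet seen in this assay with a 4.7-fold higher unbound fraction from compound 2 to compound 3 (0.67 log units; beyond the scatter) and with a 14-fold higher unbound fraction from compound 1 to compound 3 (1.15 log units; beyond the scatter) as the wider span across this position. Within the data shown here, the earlier pair showed only that the group on this sulfur can move the read-out, whereas the three compounds now rank by unbound fraction, with compound 1 lowest, compound 2 in the middle and compound 3 highest, so the two chlorine-bearing groups stand at opposite ends and the presence of chlorine does not order the series. No supporting data on hand account for this shift.

Still open, from the compounds shown here alone, is how an unsubstituted phenyl, or a phenyl carrying an amine or a carboxylic acid, would behave on this sulfur. Also open, going by these compounds, is whether the gain from 3,4-dichlorophenyl holds when the rest of the shared core changes.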